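Benzamido Replaces Pyridinyloxy on a Benzisoxazole Acid Series

A few compounds are considered here, and "the series" means these few. Any claim that something is new, unique, unknown or untested is made for them only; others in the source may bear on it.

The measured compounds, with their results in an assay for inhibition of inositol hexakisphosphate kinase 2 (Homo sapiens), read by colorimetric assay, coupled enzyme assay and malachite green, with a stated time of 120 min, in the presence of a further agent that is not named here; a lower number here means a stronger inhibitor, a higher number a weaker inhibitor:

Compound 1 `CNC(=O)/C=C/c1ccc2noc(-c3ccccc3)c2c1`: 58200 nM
Compound 2 `O=C(O)/C=C/c1ccc2noc(-c3ccc(-c4ccccc4)cc3)c2c1`: 74 nM
Compound 3 `O=C(O)c1ccc2noc(-c3ccc(Oc4ccccn4)cc3)c2c1`: 1190 nM

All three share a core, and they differ in the acid-bearing side and in the group hanging off the pendant phenyl ring. Compound 3 carries a carboxylic acid directly on the core and a (pyridin-2-yl)oxy group on that phenyl ring. Among the three numbers it stands second highest: compound 2 sits well below it, beyond the usual scatter, while compound 1 sits far above it, also beyond the scatter. Compound 3 is therefore neither the strongest nor the weakest inhibitor here.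

The next compound, compound 4 `O=C(O)c1ccc2noc(-c3ccc(NC(=O)c4ccccc4)cc3)c2c1`, keeps the acid on the core and changes only the pendant group: benzamido in place of (pyridin-2-yl)oxy on an aromatic carbon. Within the data shown here, no measured pair shows exactly this exchange, so its effect must be guessed. Compound 2, with a plain phenyl extension, gives 74 nM, which hints that a large carbon-only ring in that position can be tolerated. A modest change is expected, without a firm direction, and the estimate for compound 4 is 700 nM (between 150 nM and 3000 nM), a step of a 1.7-fold lower number from compound 3 to compound 4 (0.23 log units; within the scatter) expected from the measured value of compound 3.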

Compound 4, half-maximal inhibitory concentration: 580 nM
Compound 4: middle estimate off by 1.2-fold (0.08 log units), on the high side; the measured number falls inside the stated range.
By their numbers in this assay, from the lowest: compound 2; then compound 4; then compound 3; then compound 1.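

In this assay, exchanging (pyridin-2-yl)oxy for benzamido gives a 2.1-fold lower number from compound 3 to compound 4 (0.31 log units; beyond the scatter), a modest step that still lies beyond the usual scatter. Among these compounds, this is the first pair that differs in one place only, so it gives the first direct reading for this aromatic carbon, para to a large group: the larger benzamido, with 9 heavy atoms against 7, is accepted here and the number moves down rather than up. Nothing measured among these data accounts for the step.

The exchange alters two things together, the link to the phenyl ring and the outer ring itself, which loses its ring nitrogen, so the compounds shown cannot say which of the two carries the step; a phenoxy group, or a pyridine-2-carboxamido group, at the same place would separate them. Also open, as far as these compounds go, is whether the step holds with a different acid-bearing side, such as the propenoic acid chain of compound 2, and whether a substituent such as an amine on the outer ring of benzamido moves the number further.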